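Compound 3 loses its chloro group

A few compounds are considered here, and "the series" means these few. Any claim that something is new, unique, unknown or untested is made for them only; others in the source may bear on it.

In a toxicity assay on Huh-7.5 cells (Homo sapiens) for inhibition, read by MTT assay, with a stated time of 96 h (a lower number here means that less compound is tolerated, a higher number that more compound is tolerated), compound 1 (`COc1ccc(NC(=O)c2ccc(OCCCCl)c([N+](=O)[O-])c2)cc1`) gives 39700 nM and compound 2 (`CN1CCN(Cc2ccc(NC(=O)c3ccc(OCCCCl)c(N)c3)cc2C(F)(F)F)CC1`) gives 12900 nM while compound 3 (`CCC(=O)Nc1cc(C(=O)Nc2ccc(OC)cc2)ccc1OCCCCl`) gives 158000 nM as the highest of the three numbers. Compound 4 (`CCCOc1ccc(C(=O)Nc2ccc(OC)cc2)cc1NC(=O)CC`) departs from compound 3 in one place (hydrogen in place of chloro on a saturated chain carbon, three bonds along the chain from an oxygen on an aromatic ring) with hydrogen in place of chloro on a saturated chain carbon, three bonds along the chain from an oxygen on an aromatic ring, so that 3-chloropropyl becomes propyl. The only measured step between two of these compounds (a 4.0-fold higher number from compound 1 to compound 3 (0.60 log units; beyond the scatter)) is a modest one, and it puts propanoylamino in place of nitro, leaving the 3-chloropropyl group untouched. All three measured compounds carry that group, so the data do not show what its loss does. No step beyond the scatter is therefore expected in this assay and no direction can be favoured. The estimated step (a 1.1-fold higher number from compound 3 to compound 4 (0.03 log units; within the scatter)) is correspondingly small. Compound 4 is expected at about 170000 nM with an estimated range from 70000 nM to 400000 nM in this measurement.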

Compound 4, half-maximal cytotoxic concentration: 106000 nM
Beside the measured number, compound 4's estimate is 1.6-fold (0.21 log units) above it, and the stated range covers the measured number.
By their numbers in this assay, from the lowest: compound 2; then compound 1; then compounds 4 and 3 (each within the scatter of the next).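

The step is a 1.5-fold lower number from compound 3 to compound 4 (0.17 log units; within the scatter) in this assay, so with hydrogen in place of chloro, compound 3 and compound 4 cannot be told apart. Among these compounds, all the earlier compounds carried the 3-chloropropyl group, and this pair is the first to show that, on this core with propanoylamino, propyl is tolerated at a level that cannot be separated from that of 3-chloropropyl. No measured evidence accompanies this result to account for it.

The compounds shown leave open whether the same exchange would read alike in compound 1 and compound 2, which both keep the 3-chloropropyl group. They also leave open what an amine, a carboxylic acid or a longer chain would give in place of the chloro group on this chain.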